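This account rests on a few compounds, and the source may have more. Where it says the series, first, only, none or still open, it means among the compounds named here.

In an ADME assay on MDBK cells (Bos taurus) for cytotoxicity, read by MTT assay, with a stated time of 96 h (a lower number here means that less compound is tolerated, a higher number that more compound is tolerated), compound 1 `O=C(NC(=S)Nc1cccc(C(F)(F)F)c1)c1ccccc1` gives > 100000 nM, which is a limit of the assay and not a number. Compound 2 `CCCC[C@H]1CC[C@H](c2ccc(NC(=S)Nc3cccc(C(F)(F)F)c3)cc2)CC1` gives an actual number, 10000 nM. Compound 3 `O=C(NC(=S)Nc1cccc(C(F)(F)F)c1)[C@H]1C[C@@H]2CC[C@H]1C2` keeps the core of compound 1 and replaces one group on a carbonyl carbon: a group of 7 heavy atoms (7 carbon; 2 five-membered non-aromatic rings of carbon only) in place of a group of 6 heavy atoms (6 carbon; one six-membered aromatic ring of carbon only), on a carbonyl carbon. Among the compounds with values here, no measured pair shows what such a swap does, so the expectation rests on compound 1 and its reading of > 100000 nM. Little or no change is expected, with any shift likely toward less compound being tolerated, and the estimated step is an at least 1.2-fold lower number from compound 1 to compound 3 (0.09 log units; that floor lies within the scatter). For compound 3, the expected value is 80000 nM, with an estimated range from 30000 nM to 100000 nM.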

Compound 3, half-maximal cytotoxic concentration: 10000 nM
Beside the measured number, compound 3's estimate is 8.0-fold (0.90 log units) above it; measured number outside the range, below it.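

In this assay, swapping phenyl on this carbonyl carbon for the group with 2 five-membered non-aromatic rings of carbon only gives an at least 10-fold lower number from compound 1 to compound 3 (1.00 log units; beyond the scatter), so this place can change how much compound is tolerated. The reading for compound 1 is a limit of the assay and not a number, so the step gives only a floor: the limit of > 100000 nM in this assay, at which 1 of the 3 values shown sits.

Going by these compounds, whether the loss of the aromatic ring or the new ring system drives the shift stays open. So does the effect of a cyclohexyl group or an amine at this place.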